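Swapping pyrrolidin-1-yl for piperidin-1-yl on a carbonyl carbon

A few compounds are considered here, and "the series" means these few. Any claim that something is new, unique, unknown or untested is made for them only; others in the source may bear on it.

Values in a functional assay on A549 cells (Homo sapiens) for cytotoxicity, with a stated time of 60 h (on this read-out higher numbers stand for an effect only at larger amounts of compound and lower numbers for an effect already at smaller amounts), are these:

- Compound 1 `CCN(CC)C(=O)c1c(NC(=O)c2ccccc2)sc2c1CCCC2` gives > 30000 nM (a limit)
- Compound 2 `NC(=O)c1c(NC(=O)c2cccs2)sc2c1CCCC2` gives < 30000 nM (a limit)
- Compound 3 `O=C(Nc1sc2c(c1C(=O)N1CCCC1)CCCC2)c1cccs1` gives 3100 nM (a number)

In this assay, for the measured compounds named here, compound 3 is the only one with a true number, and the other two results are limits. Compound 4 `O=C(Nc1sc2c(c1C(=O)N1CCCCC1)CCCC2)c1cccs1` keeps the shared core and differs from compound 3 in one group (piperidin-1-yl in place of pyrrolidin-1-yl on a carbonyl carbon). Piperidin-1-yl stands in place of pyrrolidin-1-yl on a carbonyl carbon.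

Going by the values given here, only one measured step touches this place (a step that the limit leaves unreadable from compound 2 to compound 3). Among the compounds with values here, its size cannot be read, and no measured pair exchanges these two groups. With no size to carry over, the expectation stays close to compound 3 at 3100 nM and no step beyond the usual scatter is expected in this assay in either direction. The estimated step (a 1.0-fold lower number from compound 3 to compound 4 (0.01 log units; within the scatter)) carries a wide uncertainty. Compound 4 is estimated at 3000 nM within an expected range (1000 nM to 10000 nM).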

Compound 4, half-maximal effective concentration: 5100 nM
Compound 4: the middle estimate sits 1.7-fold (0.23 log units) below what was measured; the range from low to high includes it.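

In this assay, for the compounds shown here, there is now a 1.6-fold higher number from compound 3 to compound 4 (0.22 log units; within the scatter) and this is the first step at this place, on a carbonyl carbon, whose size can be read. Going from the five-membered pyrrolidin-1-yl ring to the six-membered piperidin-1-yl ring, one heavy atom larger, therefore gives no difference that can be told apart from the scatter of repeated measurements. The steps from compound 2 to these two compounds cannot be read because compound 2 carries a limit: the limit of < 30000 nM in this assay, at which 1 of the 4 values shown sits.

So how far the simple amino group of compound 2 differs from either ring remains unknown. Also open, on these data alone, is how the read-out would respond on the same carbonyl carbon to a smaller ring such as azetidin-1-yl, or to a ring with an added oxygen atom such as morpholin-4-yl.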